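The compounds below may be only part of what the source reports. "The series", "measured", "known", "first", "only" and "open" are said of these compounds alone.

Measured compounds in this series:

compound 1, `O=C(CSc1nncnc1-c1ccccc1Cl)Nc1ccccn1`: 172000 nM
compound 2, `O=C(CSc1nncnc1-c1ccccc1Cl)Nc1ccccc1`: 127000 nM
compound 3, `O=C(CSc1nncnc1-c1ccccc1Cl)Nc1ccccc1Cl`: 90000 nM

All three were read in an ADME assay on MT4 cells (Homo sapiens) for cytotoxicity, read by MTT assay; on this read-out higher numbers stand for lower toxicity in this test and lower numbers for higher toxicity in this test. Compound 3 gives the lowest of the three numbers, but its gap to compound 2, a 1.4-fold lower number from compound 2 to compound 3 (0.15 log units; within the scatter), and its gap to compound 1, a 1.9-fold lower number from compound 1 to compound 3 (0.28 log units; within the scatter), both sit within the scatter, so the three compounds cannot be ordered on these numbers. The remaining step, a 1.4-fold lower number from compound 1 to compound 2 (0.13 log units; within the scatter), is likewise within the scatter.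

Compound 4, `O=C(CSc1nncnc1-c1ccccc1Cl)c1ccc(Br)cc1Br`, has not yet been measured in this assay. Its difference from compound 3 is 2,4-dibromophenyl in place of (2-chlorophenyl)amino on a carbonyl carbon. Among the measured compounds shown here, none of the measured steps touches this position in this way: all three steps vary the ring on the amide-type nitrogen while keeping the (aryl)amino pattern, whereas compound 4 replaces that whole (2-chlorophenyl)amino group with 2,4-dibromophenyl on the carbonyl carbon. The measured steps therefore bear on it only loosely; what they do show is that changes in this region of the shared core gave no shift beyond the scatter. On that basis no step beyond the scatter is expected in this assay, with the direction left open; compound 4 is estimated at 75000 nM, range 25000 nM to 220000 nM, a step of a 1.2-fold lower number from compound 3 to compound 4 (0.08 log units; within the scatter) from compound 3.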

Compound 4, half-maximal cytotoxic concentration: 28000 nM
Beside the measured number, compound 4's estimate is 2.7-fold (0.43 log units) above it, within the range that was stated.
By their numbers in this assay, from the lowest: compound 4; then compounds 3, 2 and 1 (each within the scatter of the next).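

Among the compounds shown here, compound 4 gives the first change that lies beyond the scatter in this assay: putting 2,4-dibromophenyl on the carbonyl carbon in place of the arylamino groups lowers the number in all three comparisons (a 3.2-fold lower number from compound 3 to compound 4 (0.51 log units; beyond the scatter); a 4.5-fold lower number from compound 2 to compound 4 (0.66 log units; beyond the scatter); a 6.1-fold lower number from compound 1 to compound 4 (0.79 log units; beyond the scatter)). The earlier swaps of the ring on the amide-type nitrogen stayed within the scatter, so this position responds when the whole amino-linked group is replaced, and the shift is towards higher toxicity in this test. All three steps are modest, and the change also takes away the hydrogen-bond donor that the amino-linked groups carry. Nothing available speaks to the reason for this shift.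

The compounds shown leave open whether the step follows from losing the amino nitrogen or from the two bromines, as both change together in compound 4. A plain phenyl on the carbonyl carbon and a (2,4-dibromophenyl)amino group would pull these apart, and a morpholine or a carboxylic acid at the same place would show how far the response extends.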